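Ring-size change on the imine nitrogen of compound 2

The source may report more compounds than this note shows. Statements on the series, on what has been measured and on what is new or still open speak of the compounds shown alone.

Measured so far:
compound 1 `CN(/C(=N/C1CCCCC1)SCC1=CSC2=NCCN12)C1CCCCC1`: 3580 nM
compound 2 `C1=C(CS/C(=N\C2CCCCCC2)NC2CCCCCC2)N2CCN=C2S1`: 25 nM

In an assay on CCRF-CEM cells for displacement of a labelled ligand from C-X-C chemokine receptor type 4 (Homo sapiens) (a lower number here means a stronger inhibitor, a higher number a weaker inhibitor), compound 2 gives 25 nM and stands lowest of the two numbers in hand. Among the compounds with values here, compound 1 gives 3580 nM in this assay, a far higher number; compound 1 differs from compound 2 in more than one place at once, so no single step between them is defined and the pair shows only that the two values lie well apart, beyond the scatter.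

Compound 3 `C1=C(CS/C(=N\C2CCCCC2)NC2CCCCCC2)N2CCN=C2S1` is not yet measured. It differs from compound 2 in one place: cyclohexyl in place of cycloheptyl on a double-bonded nitrogen. Within the data shown here, no measured pair shows this change alone, so its effect is not known from the series. A ring one atom smaller at this position is a small change, and the expectation is a step from compound 2 of modest size, more likely toward a higher number than a lower one, and possibly within the scatter.

For compound 3 the expected value in this assay is 50 nM (range 15 nM to 200 nM), which would mean an expected step of a 2.0-fold higher number from compound 2 to compound 3 (0.30 log units; within the scatter).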

Compound 3, half-maximal inhibitory concentration: 28 nM
Compound 3: middle estimate off by 1.8-fold (0.25 log units), on the high side; low and high end bracket the measured number.
By their numbers in this assay, from the lowest: compounds 2 and 3 (each within the scatter of the next); then compound 1.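

In this assay cyclohexyl and cycloheptyl on the double-bonded nitrogen cannot be told apart, with a 1.1-fold higher number from compound 2 to compound 3 (0.05 log units; within the scatter) as the step, so this position tolerates a ring of either size in the presence of cycloheptylamino on the carbon with a double bond to nitrogen. Compound 3 also gives the series its first single-place comparison with compound 1, and a 130-fold lower number from compound 1 to compound 3 (2.11 log units; beyond the scatter) follows from cycloheptylamino in place of cyclohexyl(methyl)amino on that carbon, which places a large difference at this site rather than on the double-bonded nitrogen. No evidence in hand gives a reason for either step.

The large step combines the loss of the methyl group with the change in ring size, and cyclohexylamino on the same carbon would be needed to separate the two. Going by these compounds, the tolerance on the double-bonded nitrogen rests on two neighbouring ring sizes only, so a cyclopentyl ring, an open hexyl chain or a piperidine ring at this position remains open.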